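Carboxy in Place of Nitro on Compound 1

The source may report more compounds than this note shows. Statements on the series, on what has been measured and on what is new or still open speak of the compounds shown alone.

Compound 1 `O=C(Oc1cccc2ccccc12)c1cccc([N+](=O)[O-])c1`: 24600 nM
Compound 2 `O=C(Nc1cccc(-c2ccccc2)c1)c1cc([N+](=O)[O-])cc([N+](=O)[O-])c1`: > 50000 nM

In an assay on isolated protein (blood) for inhibition of Polyunsaturated fatty acid 5-lipoxygenase (Homo sapiens), read by ELISA, with stated times of 15 min and 30 min (on this read-out lower numbers stand for stronger inhibition and higher numbers for weaker inhibition), compound 1 gives 24600 nM and is the only number shown. Compound 2 reaches only (the limit of > 50000 nM in this assay, at which 1 of the 2 values shown sits), which is a limit of the assay and not a number. As far as these compounds go, compound 3 `O=C(O)c1cccc(C(=O)Oc2cccc3ccccc23)c1` is untested; it differs from compound 1 by carboxy in place of nitro on an aromatic carbon. Among the measured compounds shown here, no step between measured compounds exists to guide the size of this change, so the expectation is for no shift beyond the usual scatter. Compound 3 is therefore expected to give 22000 nM, between 5000 nM and 80000 nM, a step of a 1.1-fold lower number from compound 1 to compound 3 (0.05 log units; within the scatter).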

Compound 3, half-maximal inhibitory concentration: > 50000 nM
Compound 3 ended at the assay's limit (the forecaster's own chance of this, stated with the estimate: 35%); middle value at least 2.2-fold (0.35 log units) away from the limit.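

Among the compounds shown here, on the core of compound 1, carboxy in place of nitro on this aromatic carbon gives the first readable step in this assay: an at least 2.0-fold higher number from compound 1 to compound 3 (0.30 log units; that floor lies within the scatter). As far as these compounds go, compound 3 stands at a limit and not a number, so the change shows no gain in inhibition, while the true size of any loss stays unknown. Compound 3 also joins compound 2 at the same limit: the limit of > 50000 nM in this assay, at which 2 of the 3 values shown sit.

The compounds shown leave open how an amine or a methyl ester would read on this same carbon.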